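From 4-methylphenyl to 2-methoxyphenyl in compound 1

This account rests on a few compounds, and the source may have more. Where it says the series, first, only, none or still open, it means among the compounds named here.

Values in a functional assay on Jurkat cells (Homo sapiens) for antiproliferative activity, read by MTT assay, with a stated time of 72 h; a higher number here means a weaker inhibitor, a lower number a stronger inhibitor:
compound 1 `COc1cc(-n2ncnc2-c2ccc(C)cc2)cc(OC)c1OC`: 300 nM
compound 2 `COc1cc(-c2ncnn2-c2ccc(N)cc2)cc(OC)c1OC`: > 10000 nM (a limit of the assay, not a number)
compound 3 `COc1cc(-c2ncnn2-c2ccc(Cl)c(Cl)c2)cc(OC)c1OC`: > 10000 nM (a limit of the assay, not a number)

Within the data shown here, compound 1 holds the only true number in this small set. The other two values stand at the limit of > 10000 nM in this assay, at which 2 of the 3 values shown sit. Compound 4 `COc1ccccc1-c1ncnn1-c1cc(OC)c(OC)c(OC)c1` keeps the core of compound 1 and exchanges one group: 2-methoxyphenyl in place of 4-methylphenyl on an aromatic carbon. Here 2-methoxyphenyl replaces 4-methylphenyl on an aromatic carbon of the five-membered aromatic ring with 3 nitrogen.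

Among the measured compounds shown here, the one measured step gives no guidance on size: a step that the two limits leave unreadable from compound 2 to compound 3. For the measured compounds named here, no measured step covers this exchange, so any forecast is rough. Going by the values given here, compound 1 at 300 nM is the only compound with a readable value, so a move toward weaker inhibition in this assay is expected rather than a gain. The expected change is a 3.3-fold higher number from compound 1 to compound 4 (0.52 log units; beyond the scatter), with wide uncertainty. For compound 4 the estimated value is 1000 nM, with an expected range from 100 nM to 8000 nM.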

Compound 4, half-maximal inhibitory concentration: > 10000 nM
Compound 4: only a limit was reported; the forecaster's own chance of this, stated with the estimate: 20%; at least 10-fold (1.00 log units) between middle value and limit.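

In this assay, placing 2-methoxyphenyl instead of 4-methylphenyl on this aromatic carbon gives an at least 33-fold higher number from compound 1 to compound 4 (1.52 log units; beyond the scatter), so this place does not accept every substituted phenyl group equally. Compound 4 gives > 10000 nM, which is a limit of the assay and not a number. Compound 1 therefore remains the only compound with a readable value, and the true size of the loss stays unknown, with most of the set resting on the same limit: the limit of > 10000 nM in this assay, at which 3 of the 4 values shown sit.

The exchange changes both the substituent and where it sits on the phenyl ring, so the compounds shown cannot say which of the two matters. 2-Methylphenyl would test the new location with the methyl group kept, and 4-methoxyphenyl would test the methoxy group in the location the methyl group holds in compound 1.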